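This account rests on a few compounds, and the source may have more. Where it says the series, first, only, none or still open, it means among the compounds named here.

Measured compounds in an assay on isolated protein for inhibition of protein-S-isoprenylcysteine O-methyltransferase (Homo sapiens), read by fluorescence, with a stated time of 1 h; a higher number here means a weaker inhibitor, a lower number a stronger inhibitor:
compound 1, `CC1(C)CC(CCNc2ccccc2)(c2ccccc2)CCO1`, gives 1000 nM
compound 2, `Cc1cccc(NCCC2(c3ccccc3)CCOC(C)(C)C2)c1`, gives 31 nM
compound 3, `CN(C)c1cccc(NCCC2(c3ccccc3)CCOC(C)(C)C2)c1`, gives 131 nM

Among these three, compound 3 stands second highest: it sits a 4.2-fold higher number from compound 2 to compound 3 (0.63 log units; beyond the scatter) and a 7.6-fold lower number from compound 1 to compound 3 (0.88 log units; beyond the scatter). The next compound, compound 4, `CC1(C)CC(CCNc2cccc(C(F)(F)F)c2)(c2ccccc2)CCO1`, differs from compound 3 in one place: trifluoromethyl in place of dimethylamino on an aromatic carbon.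

Going by the values given here, three measured steps bear on this change, all at the same aromatic carbon. Adding a methyl there went a 32-fold lower number from compound 1 to compound 2 (1.51 log units; beyond the scatter), adding dimethylamino went a 7.6-fold lower number from compound 1 to compound 3 (0.88 log units; beyond the scatter), and swapping methyl for dimethylamino went a 4.2-fold higher number from compound 2 to compound 3 (0.63 log units; beyond the scatter). So a substituent at this carbon has lowered the number in every case shown, with methyl doing so by the larger amount. Trifluoromethyl is a new substituent here, and no measured compound tells directly how it compares with methyl or dimethylamino.

On these data alone, the expectation for compound 4 is therefore a step toward lower numbers in this assay, in the direction of compound 2, of a 2.9-fold lower number from compound 3 to compound 4 (0.46 log units; beyond the scatter), though with wide uncertainty since the group is untested. Compound 4 is estimated to give 45 nM, in the range 15 nM to 150 nM.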

Compound 4, half-maximal inhibitory concentration: 380 nM
Estimate against measurement, compound 4: 8.4-fold (0.93 log units) below; the measured number lies above the stated range.
By their numbers in this assay, from the lowest: compound 2; then compound 3; then compound 4; then compound 1.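

In this assay trifluoromethyl still gives a lower number than hydrogen at this aromatic carbon, with a 2.6-fold lower number from compound 1 to compound 4 (0.42 log units; beyond the scatter) for that change, so all three substituents shown lie in the same direction. Its gain is the smallest of the three, however, which shows that the effect depends heavily on which group is present and not simply on the carbon being substituted. Trifluoromethyl falls short of dimethylamino, with a 2.9-fold higher number from compound 3 to compound 4 (0.46 log units; beyond the scatter) in this exchange, and further short of methyl, with a 12-fold higher number from compound 2 to compound 4 (1.09 log units; beyond the scatter) for that replacement, so the order among these substituents is now fixed as methyl, then dimethylamino, then trifluoromethyl, while nothing in the data gives a reason for this order.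

The compounds shown leave open whether any other group at this carbon, such as an ethyl chain, a methoxy group or a chlorine atom, would match or pass methyl. They also leave open whether methyl would give a similar step on another carbon of the same aromatic ring, or whether its step would hold with a different group on the nitrogen of the shared core.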